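Compound 2 to Compound 4: An Expected Limit

The source may report more compounds than this note shows. Statements on the series, on what has been measured and on what is new or still open speak of the compounds shown alone.

Of the compounds shown here, three sharing one core have been tested in a functional assay on B16-BL6 cells (Mus musculus) for cytotoxicity, read by MTT assay, with a stated time of 48 h; a higher number here means a weaker inhibitor, a lower number a stronger inhibitor. Compound 1, `CNC(=O)c1ccc(Sc2ccc(NC(=S)Nc3ccc(OC(F)(F)F)cc3)cc2)nc1`, gives > 100000 nM in this assay, which is a limit of the assay rather than a number. Compound 2, `CNC(=O)c1ccc(Sc2cccc(NC(=S)Nc3ccc(F)c(Cl)c3)c2)nc1`, gives > 100000 nM in this assay, again a limit and not a measured number. Compound 3, `CNC(=O)c1ccc(Sc2ccc(NC(=O)Nc3ccc(F)c(C(F)(F)F)c3)cc2)nc1`, is the only one of the three with an actual number: in this assay compound 3 gives 39600 nM. Compound 2 therefore stands at the limit of > 100000 nM in this assay, at which 2 of the 3 values shown sit, and no finer reading of its potency is available.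

Compound 4, `CNC(=O)c1ccc(Sc2cccc(NC(=S)Nc3cccc(C(F)(F)F)c3)c2)nc1`, is the untested partner of compound 2. The change between them is 3-(trifluoromethyl)phenyl in place of 3-chloro-4-fluorophenyl on an amide-type nitrogen. Everything else in the two structures, including the amide-type nitrogen and the thiocarbonyl carbon it is attached to, stays the same. Because compound 2 sits at the limit of > 100000 nM in this assay, at which 2 of the 3 values shown sit, the step of a number no higher from compound 2 to compound 4 (the limit leaves the size open) is expected to be none beyond the usual scatter, with the new compound most likely again reported only as a limit. Compound 4 is estimated at 100000 nM, within a range from 30000 nM to 300000 nM.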

Compound 4, half-maximal inhibitory concentration: 19200 nM
Compound 4: the middle estimate sits 5.2-fold (0.72 log units) above what was measured, and the stated range ends above it.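

Replacing 3-chloro-4-fluorophenyl with 3-(trifluoromethyl)phenyl on the amide-type nitrogen attached to the thiocarbonyl carbon gives an at least 5.2-fold lower number from compound 2 to compound 4 (0.71 log units; beyond the scatter) in this assay. Among these compounds, the three earlier compounds differ from one another in more than one place, so they gave no single change to read; this pair is the first to show that the group at this position can alter the result on its own, with compound 4 giving an actual number of 19200 nM. The true size of the step stays open on one side, and it could be larger than the figure printed, because the starting point of the step is a limit and not a number: the limit of > 100000 nM in this assay, at which 2 of the 4 values shown sit.

With only this one replacement in view, the result cannot be assigned to losing the chlorine, losing the ring fluorine or gaining the trifluoromethyl group. A plain phenyl ring, or a ring carrying a methoxy group or a nitrile, would help separate these possibilities, and the compounds shown do not say whether the same swap would lower the number with a carbonyl in place of the thiocarbonyl.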